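This account rests on a few compounds, and the source may have more. Where it says the series, first, only, none or still open, it means among the compounds named here.

Measured compounds:
compound 1 `Cc1cc(C(=O)O)c(C)[nH]1` — > 100000 nM
compound 2 `Cc1cc(C(=O)O)c(C)n1-c1cccc(C#N)c1F` — 630 nM
compound 3 `O=C(O)C1CCN(c2cccc(C(F)(F)F)c2)C1` — 11000 nM

In an assay on cells for inhibition of Palmitoleoyl-protein carboxylesterase NOTUM variant C330S (Homo sapiens), read by fluorescence, with a stated time of 40 min (on this read-out lower numbers stand for stronger inhibition and higher numbers for weaker inhibition), compound 1 gives > 100000 nM, which is a limit of the assay and not a number; this is the limit (the limit of > 100000 nM in this assay, at which 1 of the 3 values shown sits). Compound 2 gives 630 nM in this assay, and compound 3 gives 11000 nM. Of the two numbers shown, compound 3 carries the higher one; the gap to compound 2 lies beyond the usual scatter, so compound 3 stands as the weaker of the two compounds with a number.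

Compound 4 `N#Cc1cccc(N2CCC(C(=O)O)C2)c1` has not yet been measured in this assay. It differs from compound 3 by cyano in place of trifluoromethyl on an aromatic carbon, with the rest of the molecule unchanged. Among the compounds with values here, no step between two measured compounds covers this exchange on the core of compound 3, so the direction of the step is open. The expectation is a step of a 1.4-fold higher number from compound 3 to compound 4 (0.13 log units; within the scatter), of a size that may not exceed the usual scatter. Compound 4 is expected to give about 15000 nM in this assay, with a likely range from 4000 nM to 50000 nM.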

Compound 4, half-maximal inhibitory concentration: 42000 nM
Compound 4: the middle estimate sits 2.8-fold (0.45 log units) below what was measured, and the stated range covers the measured number.
By their numbers in this assay, from the lowest: compound 2; then compound 3; then compound 4. At a limit, above all of these: compound 1.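

In this assay, within the data shown here, the exchange of trifluoromethyl for cyano on an aromatic carbon, meta to a group of 8 heavy atoms, gives the first step between two measured compounds that differ in one place: a 3.8-fold higher number from compound 3 to compound 4 (0.58 log units; beyond the scatter). The position is therefore not indifferent to its substituent, and on the core of compound 3 the trifluoromethyl compound carries the lower number, although the step is modest and both numbers remain in the micromolar range. Nothing shown here explains the direction or size of this step.

With only two substituents compared at this position, the results define no trend, and a chlorine atom, a methoxy group or a plain hydrogen there would show whether trifluoromethyl is itself favourable or cyano is unfavourable. From the compounds shown here alone, it also remains open whether the same exchange would give a step of similar direction and size on the core of compound 2, or whether an amide in place of the carboxylic acid would keep any of the inhibition seen on the core of compound 3.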